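The source may report more compounds than this note shows. Statements on the series, on what has been measured and on what is new or still open speak of the compounds shown alone.

In an ADME assay on L929 cells (Mus musculus) for cytotoxicity, read by resazurin assay, with a stated time of 72 h (a lower number here means a stronger inhibitor, a higher number a weaker inhibitor), three compounds have so far been measured.

Compound 1 `OB1OCc2ccc(-n3ccc4ccccc43)cc21` gives only a limit of the assay, > 10 ug/mL.
Compound 2 `OB1OCc2ccc(-n3cc(Sc4ccc(O)cc4)c4ccccc43)cc21` likewise gives only a limit, > 10 ug/mL.
Compound 3 `O=C(c1ccn(-c2ccc3c(c2)B(O)OC3)c1)c1ccccc1Cl` also gives only a limit, > 10 ug/mL.

Going by the values given here, compound 3 therefore stands nowhere in particular on a scale of numbers: it sits at the same limit as the other two, at the limit of > 10 ug/mL in this assay, at which 3 of the 3 values shown sit, and no compound here has produced a readable number. Among the compounds with values here, the one step that can be drawn between measured compounds, from compound 1 to compound 2, is a step that the two limits leave unreadable from compound 1 to compound 2, since both ends are limits.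

The next compound, compound 4 `Cc1ccccc1C(=O)c1ccn(-c2ccc3c(c2)B(O)OC3)c1`, differs from compound 3 by methyl in place of chloro on an aromatic carbon. Within the data shown here, no measured step bears on this change in this assay; the only step available is unreadable, and the three values all sit at the limit. With nothing pointing toward a stronger effect, the expectation is that compound 4 will behave like compound 3 and again reach the limit rather than a number, so that the step that the limit leaves unreadable from compound 3 to compound 4 is expected to be no step beyond the scatter. Compound 4 is therefore estimated at 15 ug/mL, within a range from 5 ug/mL to 50 ug/mL.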

Compound 4, half-maximal inhibitory concentration: > 10 ug/mL
Compound 4 gave a limit, no number (the forecaster's own chance of this, stated with the estimate: 80%); the middle value does not contradict the limit.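

Compound 3 and compound 4 both give only a limit, so no step can be read for methyl in place of chloro. The compounds shown leave open where any of them would fall on a scale of numbers in this assay, and whether any change to them moves the read-out at all: the limit of > 10 ug/mL in this assay, at which 4 of the 4 values shown sit.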